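The source may report more compounds than this note shows. Statements on the series, on what has been measured and on what is new or still open speak of the compounds shown alone.

Values measured so far in a functional assay on Caco-2 cells (Homo sapiens) for inhibition, read by MTT assay, with a stated time of 48 h, tested at 10 uM; a lower number here means less inhibition of growth, a higher number more inhibition of growth at the concentration tested

- Compound 1 (`Cc1cc(=O)c2c(O)cc(OC/C=C/c3ccccc3)c([C@H]3CCN(C)C[C@H]3O)c2o1`) gives 9%
- Compound 2 (`CCN(CC)Cc1c(O)c([C@H]2CCN(C)C[C@H]2O)c2oc(C)cc(=O)c2c1O`) gives 17%

Compound 2 at 17% and compound 1 at 9% lie within the scatter of each other, so the two cannot be ranked. Both numbers are small on a scale of growth inhibition.

The next compound, compound 3 (`Cc1cc(=O)c2c(O)c(CN3CC(O)CC3C(=O)O)c(O)c([C@H]3CCN(C)C[C@H]3O)c2o1`), keeps the rest of compound 2 and changes one group. It carries 2-carboxy-4-hydroxypyrrolidin-1-yl in place of diethylamino on a saturated chain carbon bound to an aromatic carbon. The entering group is larger and has a ring, and it counts more hydrogen-bond donors and acceptors than the group that leaves.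

For the measured compounds named here, no pair of measured compounds differs in one place only, so the data give no direct guide to the size of this step. With compound 2 starting from only 17% in this assay as its base, no step beyond the scatter is expected, and a small drop is the likeliest direction.

The expected change is a number 5 percentage points lower from compound 2 to compound 3 (within the scatter) in this estimate. For compound 3 the estimated value is 12% with an expected range from 0% to 28% in the same test.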

Compound 3, percent growth inhibition at one concentration: 19%
Compound 3: middle estimate off by 7 percentage points, on the low side; measured number inside the range.
By their numbers in this assay, from the lowest: compounds 1, 2 and 3 (each within the scatter of the next).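

For the compounds shown here, putting 2-carboxy-4-hydroxypyrrolidin-1-yl in place of diethylamino on a saturated chain carbon bound to an aromatic carbon gives the first single-place step in this assay, and it reads a number 2 percentage points higher from compound 2 to compound 3 (within the scatter). The entering group is larger, has a ring and counts more hydrogen-bond donors and acceptors, yet this exchange leaves the read-out within the scatter, so at the concentration tested these differences in the group do not separate the two compounds. Nothing available explains this result.

As far as these compounds go, the carboxylic acid, the hydroxyl and the ring all enter in one step, so their separate contributions remain open, and a plain pyrrolidin-1-yl group at the same place would be needed to begin telling them apart. Also open, from the compounds shown here alone, is whether any other amine here, such as morpholin-4-yl or piperazin-1-yl, would give a number beyond the scatter of compound 2 , or whether the read-out at this place stays small whichever amine is attached.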